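Swapping the dichlorophenyl for a tolyl group

A few compounds are considered here, and "the series" means these few. Any claim that something is new, unique, unknown or untested is made for them only; others in the source may bear on it.

Of the compounds shown here, three of a shared core have been tested in a functional assay on Ehrlich cells (Mus musculus) for cytotoxicity (a higher number here means a weaker inhibitor, a lower number a stronger inhibitor), so far. Compound 1 `COc1ccc(C2C(C#N)=C(N)N(c3cc(OC)c(OC)c(OC)c3)C3=C2C(=O)CC(C)(C)C3)cc1` is recorded as "not active" (no number reported). Compound 2 `COc1cc(N2C(N)=C(C#N)C(/C=C/c3ccccc3)C3=C2CC(C)(C)CC3=O)cc(OC)c1OC` is likewise recorded as "not active" (no number reported). Among the compounds with values here, compound 3 `COc1cc(N2C(N)=C(C#N)C(c3ccc(Cl)cc3Cl)C3=C2CC(C)(C)CC3=O)cc(OC)c1OC` is the only one with a number: in this assay compound 3 gives 94700 nM, a weak effect, and it stands alone on the scale, since the other two entries carry no number at all.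

Compound 4 `COc1cc(N2C(N)=C(C#N)C(c3ccc(C)cc3)C3=C2CC(C)(C)CC3=O)cc(OC)c1OC` is the next step. It differs from compound 3 in one place only: 4-methylphenyl in place of 2,4-dichlorophenyl on a saturated ring carbon. Within the data shown here, no measured pair of this kind exists here, so there is no step between numbered compounds to lean on, and the size of the change can only be guessed.

The expected step from compound 3 to compound 4 is a 1.6-fold higher number from compound 3 to compound 4 (0.20 log units; within the scatter), that is, a drift toward a weaker effect that may or may not exceed the scatter. Compound 4 is therefore estimated at 150000 nM in this assay, within a range of 40000 nM to 600000 nM, with a fair chance that, like compound 1 and compound 2, it is reported without a number.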

Compound 4, half-maximal inhibitory concentration: 52900 nM
The estimate for compound 4 lay 2.8-fold (0.45 log units) above the measured number; low and high end bracket the measured number.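

In this assay, putting 4-methylphenyl in place of 2,4-dichlorophenyl on the saturated ring carbon gives a 1.8-fold lower number from compound 3 to compound 4 (0.25 log units; within the scatter) and leaves the two compounds indistinguishable on this scale. This position therefore keeps a numbered result after losing both chlorine atoms, so chlorine is not required for a number to be recorded here, and a single methyl group on the aromatic ring serves as well within the scatter. No measurement among the data shown explains why the swap changes so little.

Still open, on these data alone, is whether any group on this aromatic ring can move the number beyond the scatter, for instance an amine or a carboxylic acid. As far as these compounds go, a nitrogen-containing pyridine ring in place of the phenyl ring at this carbon is an equally open question.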